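Swapping the pyridyl group on a sulfonamide nitrogen

The compounds below may be only part of what the source reports. "The series", "measured", "known", "first", "only" and "open" are said of these compounds alone.

Compound 2 `O=S(=O)(CSc1nnc(Br)n1Cc1ccc(Br)c2ccccc12)Nc1cncc(C(F)(F)F)c1` carries a sulfonamide whose nitrogen bears a (5-(trifluoromethyl)pyridin-3-yl) group. Among the measured compounds shown here, in an assay on HEK293 cells for inhibition of solute carrier family 22 member 12 (Homo sapiens) (a lower number here means a stronger inhibitor, a higher number a weaker inhibitor), compound 2 gives 6380 nM, the lowest of the two numbers measured so far. Its nearest neighbour is compound 1 `O=S(=O)(O)CSc1nnc(Br)n1Cc1ccc(Br)c2ccccc12`, which has a sulfonic acid in place of the sulfonamide; in this assay compound 1 gives 14400 nM. For the measured compounds named here, the only measured step, a 2.3-fold lower number from compound 1 to compound 2 (0.35 log units; beyond the scatter), describes the hydroxy to (5-(trifluoromethyl)pyridin-3-yl)amino exchange on the sulfonyl sulfur, and is modest.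

Compound 3 `O=S(=O)(CSc1nnc(Br)n1Cc1ccc(Br)c2ccccc12)Nc1ccc(F)nc1` differs from compound 2 by 6-fluoropyridin-3-yl in place of 5-(trifluoromethyl)pyridin-3-yl on a sulfonamide nitrogen. Going by the values given here, no measured step covers a change of one pyridyl group for another on this nitrogen, so the measured data give no direct guide to its size or direction. Among the compounds with values here, the only known step, a 2.3-fold lower number from compound 1 to compound 2 (0.35 log units; beyond the scatter), shows that the sulfonamide aryl group moves the number only modestly when it replaces hydroxy altogether, so a change within that group is expected to move it no further than the scatter. Compound 3 is therefore expected to give about 7500 nM in this assay, between 2500 nM and 22000 nM, a step of a 1.2-fold higher number from compound 2 to compound 3 (0.07 log units; within the scatter) from compound 2.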

Compound 3, half-maximal inhibitory concentration: 1550 nM
Compound 3: middle estimate off by 4.8-fold (0.68 log units), on the high side, outside the stated range (below it).
By their numbers in this assay, from the lowest: compound 3; then compound 2; then compound 1.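

In this assay, the exchange on the sulfonamide nitrogen gives a 4.1-fold lower number from compound 2 to compound 3 (0.61 log units; beyond the scatter) and so shows that the number responds to the group on this nitrogen, even though both groups contain one six-membered aromatic ring with 1 hetero atom. Replacing hydroxy on the sulfonyl sulfur also proves to depend on which group enters: the (6-fluoropyridin-3-yl)amino group gives a 9.3-fold lower number from compound 1 to compound 3 (0.97 log units; beyond the scatter) whereas the (5-(trifluoromethyl)pyridin-3-yl)amino group gives only a 2.3-fold lower number from compound 1 to compound 2 (0.35 log units; beyond the scatter) in the same comparison. The data offer no measurement that could explain the difference between these two pyridyl groups.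

The exchange alters both the substituent, from trifluoromethyl to fluoro, and the place it holds in the group's name, so the compounds shown cannot separate these two changes. A 5-fluoropyridin-3-yl or a 6-(trifluoromethyl)pyridin-3-yl group on the same nitrogen would separate them, while an unsubstituted pyridin-3-yl group would show whether the fluoro substituent contributes to the lower number at all.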